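Ethoxy for diethylamino on the ethoxycarbonyl compound

A few compounds are considered here, and "the series" means these few. Any claim that something is new, unique, unknown or untested is made for them only; others in the source may bear on it.

- Compound 1 `CCN(CC)c1ccc(-c2ccc(C#N)cc2)nn1`: > 25000 nM (a limit, not a number)
- Compound 2 `CCOC(=O)c1ccc(-c2ccc(N(CC)CC)nn2)cc1`: 9000 nM

Both entries come from a functional assay on Huh-7 cells (Homo sapiens) for antiproliferative activity, with a stated time of 48 h; on this read-out lower numbers stand for stronger inhibition and higher numbers for weaker inhibition. Among the measured compounds shown here, compound 2 gives 9000 nM, the only true number so far. Compound 1 stands at the limit of > 25000 nM in this assay, at which 1 of the 2 values shown sits.

Compound 3 `CCOC(=O)c1ccc(-c2ccc(OCC)nn2)cc1` keeps the ethoxycarbonyl group of compound 2 and differs from it by ethoxy in place of diethylamino on an aromatic carbon. This places ethoxy in place of diethylamino on an aromatic carbon of the six-membered aromatic ring with 2 nitrogen.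

One measured step is available, an at least 2.7-fold lower number from compound 1 to compound 2 (0.44 log units; beyond the scatter). It is a modest step beyond the scatter, but it exchanges cyano for ethoxycarbonyl and leaves diethylamino untouched. For the measured compounds named here, its size therefore does not carry over, and no measured step tests the present change. In this assay no shift beyond the scatter is expected, with only a slight lean towards weaker inhibition. The expected step is a 1.3-fold higher number from compound 2 to compound 3 (0.12 log units; within the scatter). For compound 3 the estimated value is 12000 nM, with an expected range from 4000 nM to 30000 nM.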

Compound 3, half-maximal inhibitory concentration: > 25000 nM
Compound 3 was reported as a limit; the forecaster's own chance of this, stated with the estimate: 25%; at least 2.0-fold (0.31 log units) between middle value and limit.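

In this assay the aromatic carbon next to the ring nitrogen proves sensitive to its substituent: ethoxy in place of diethylamino gives an at least 2.7-fold higher number from compound 2 to compound 3 (0.44 log units; beyond the scatter) and this change lies beyond the scatter. The earlier step showed this only for the cyano and ethoxycarbonyl exchange at the other end of the molecule, whereas compound 2 now has a single-change neighbour at each end, and neither compound 1 nor compound 3 keeps a measurable value. Compound 3 stands at the limit > 25000 nM and so the step sets only a minimum size, not a measured one: the limit of > 25000 nM in this assay, at which 2 of the 3 values shown sit.

Going by these compounds, it remains open whether a smaller amine such as dimethylamino, a cyclic amine such as morpholine, or a longer alkoxy chain in place of ethoxy would hold or improve on compound 2 at 9000 nM in this assay. Equally open, on these data alone, is whether a carboxylic acid or a primary amide in place of ethoxycarbonyl would shift that number with diethylamino kept in place.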